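This account rests on a few compounds, and the source may have more. Where it says the series, first, only, none or still open, it means among the compounds named here.

Measured so far in an ADME assay on liver (Mus musculus) for metabolic stability, using microsomes, with a stated time of 10 min, tested at 0.5 uM; on this read-out lower numbers stand for a less stable compound and higher numbers for a more stable compound:

- compound 1 `Cc1ccncc1-c1cccc2c1cnn2-c1cccnn1`: 17%
- compound 2 `Cc1ccncc1-c1cccc2c1cnn2-c1ccccc1`: 4%
- compound 3 `Cc1ccncc1-c1cccc2c1cnn2-c1ccc(F)cc1`: 11%

Compound 3 stands second highest of the three numbers. Its nearest neighbour is compound 1, the gap being within the scatter; the gap to compound 2 is also within the scatter, so no order among the three can be claimed from these values alone. The two steps that leave compound 1 do differ in size: a number 13 percentage points lower from compound 1 to compound 2 (beyond the scatter), whereas a number 6 percentage points lower from compound 1 to compound 3 (within the scatter). Between the two carbon-only rings, a number 7 percentage points higher from compound 2 to compound 3 (within the scatter).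

Compound 4 `Cc1ccncc1-c1cccc2c1cnn2-c1ccccn1` differs from compound 3 in one place: pyridin-2-yl in place of 4-fluorophenyl on an aromatic nitrogen. For the measured compounds named here, the steps that bear on this exchange are those in which the pyridazin-3-yl of compound 1 was replaced by a carbon-only ring, namely a number 6 percentage points lower from compound 1 to compound 3 (within the scatter) and a number 13 percentage points lower from compound 1 to compound 2 (beyond the scatter). Pyridin-2-yl carries one ring nitrogen, fewer than pyridazin-3-yl and more than either carbon-only ring, so no step beyond the scatter is expected here, and if anything a small upward one. Compound 4 is therefore expected to give an estimated 14%, with a range of 5% to 25%. This estimate implies a number 3 percentage points higher from compound 3 to compound 4 (within the scatter), which is expected to stay within the scatter.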

Compound 4, percent of the compound remaining: 8%
For compound 4 the middle estimate is 6 percentage points above the measured one; the measured number falls inside the stated range.
By their numbers in this assay, from the lowest: compounds 2, 4, 3 and 1 (each within the scatter of the next, the first and the last beyond it).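

In this assay, pyridin-2-yl on the aromatic nitrogen gives a number 3 percentage points lower from compound 3 to compound 4 (within the scatter) and a number 4 percentage points higher from compound 2 to compound 4 (within the scatter) as well as a number 9 percentage points lower from compound 1 to compound 4 (within the scatter) so this group cannot be told apart from any of the three rings it was compared with. For the compounds shown here, compound 4 therefore stands within the scatter of both compound 1 and compound 2, the one pair whose gap lies beyond it, and the new ring does not divide the series into a group with ring nitrogen and a group without. With only that single step beyond the scatter, no trend with ring nitrogen can be claimed at this position, and nothing shown accounts for these values.

The compounds shown all carry a six-membered aromatic ring at this place, so it remains open whether pyridin-3-yl or pyridin-4-yl, with the ring nitrogen elsewhere, would read differently from pyridin-2-yl. Also open, from the compounds shown here alone, is whether a group of another kind on this nitrogen, such as a piperidine ring, a morpholine ring or a short alkyl chain ending in a carboxylic acid, would shift this assay clear of the scatter.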